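The source may hold more compounds than are shown below. What is called first, only, known or untested is meant among the compounds shown, and "the series" means these compounds.

Of the compounds shown here, two of a shared core have been tested. Compound 1 `Cc1ccc(NC2=CC(=O)c3c(nc4n3[C@H]3OC[C@@H](O)[C@H]3OC4)C2=O)cc1C` carries a (3,4-dimethylphenyl)amino group on a double-bonded ring carbon, and in a functional assay on ECa-109 cells for inhibition, with ECa-109 cell line (Homo sapiens) as the target, read by sulforhodamine B assay (on this read-out lower numbers stand for stronger inhibition and higher numbers for weaker inhibition), compound 1 gives 4090 nM. Compound 2 `O=C1C(N2CCC2)=CC(=O)c2c1nc1n2[C@H]2OC[C@@H](O)[C@H]2OC1` carries azetidin-1-yl there instead. In this assay compound 2 reaches only the assay limit of > 16000 nM, so no exact number exists for it. That change gave an at least 3.9-fold higher number from compound 1 to compound 2 (0.59 log units; beyond the scatter). Compound 3 `O=C1C(Nc2cccc(F)c2)=CC(=O)c2c1nc1n2[C@H]2OC[C@@H](O)[C@H]2OC1` differs from compound 2 in one place: (3-fluorophenyl)amino in place of azetidin-1-yl on a double-bonded ring carbon. This brings back an amino-linked phenyl group resembling that of compound 1 with its 4090 nM. Compound 3 is therefore expected to show an at least 3.2-fold lower number from compound 2 to compound 3 (0.50 log units; beyond the scatter), with an estimated 5000 nM in this assay, between 2000 nM and 16000 nM.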

Compound 3, half-maximal inhibitory concentration: 2370 nM
Compound 3: middle estimate off by 2.1-fold (0.32 log units), on the high side; low and high end bracket the measured number.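

In this assay, a second phenyl group linked through an amine on this double-bonded ring carbon again beats azetidin-1-yl, with an at least 6.7-fold lower number from compound 2 to compound 3 (0.82 log units; beyond the scatter). Compound 2 stands at an assay limit, so the true size of that step stays unknown: the limit of > 16000 nM in this assay, at which 1 of the 3 values shown sits.

The two aryl amines show a 1.7-fold lower number from compound 1 to compound 3 (0.24 log units; within the scatter), so 3-fluorophenyl and 3,4-dimethylphenyl cannot be told apart here. Still open, from the compounds shown here alone, is whether the phenyl ring or the amine hydrogen accounts for the gap to azetidin-1-yl. A benzylamino group or a piperidin-1-yl group at this place would extend the comparison.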